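The source may report more compounds than this note shows. Statements on the series, on what has been measured and on what is new or still open speak of the compounds shown alone.

Measured compounds in an assay on isolated protein (spleen, strain Sprague-Dawley) for antagonist activity at Alpha-1B adrenergic receptor (Rattus norvegicus), with a stated time of 20 min; on this read-out lower numbers stand for tighter binding and higher numbers for weaker binding:
compound 1 `COc1ccccc1N1CCN(CCCNC(=O)c2ccc3[nH]ccc3c2)CC1`, 123 nM
compound 2 `COc1ccccc1N1CCN(CCCNC(=O)Cc2c[nH]c3ccccc23)CC1`, 513 nM
compound 3 `COc1ccccc1N1CCN(CCCNC(=O)c2cc3cc(O)ccc3[nH]2)CC1`, 155 nM

Compound 3 sits among the three with compound 1 within the scatter of it (a 1.3-fold higher number from compound 1 to compound 3 (0.10 log units; within the scatter)), while the gap to compound 2 is beyond the scatter (a 3.3-fold lower number from compound 2 to compound 3 (0.52 log units; beyond the scatter)). All three share the same core and differ only in the group on the carbonyl carbon.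

Compound 4 `COc1ccccc1N1CCN(CCCNC(=O)c2cc3ccc(Br)cc3[nH]2)CC1` is not yet measured. Its change from compound 3 is 6-bromo-1H-indol-2-yl in place of 5-hydroxy-1H-indol-2-yl on a carbonyl carbon. Among the compounds with values here, no measured step swaps a hydroxy for a bromine on this group; the steps that bear on it only show that changing the indole group on the carbonyl carbon moves this assay modestly at most (a 4.2-fold higher number from compound 1 to compound 2 (0.62 log units; beyond the scatter), a 1.3-fold higher number from compound 1 to compound 3 (0.10 log units; within the scatter), a 3.3-fold lower number from compound 2 to compound 3 (0.52 log units; beyond the scatter)). Within the data shown here, the hydroxy leaving removes one donor and the only acceptor of the group, yet compound 1 lacks that hydroxy and gives 123 nM, close to compound 3. A small step, possibly within the scatter, is therefore expected in this assay, a 1.0-fold lower number from compound 3 to compound 4 (0.01 log units; within the scatter). Compound 4 is estimated at 150 nM, with a range of 50 nM to 450 nM.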

Compound 4, dissociation constant: 209 nM
Beside the measured number, compound 4's estimate is 1.4-fold (0.14 log units) below it, and the stated range covers the measured number.
By their numbers in this assay, from the lowest: compounds 1, 3 and 4 (each within the scatter of the next); then compound 2.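

In this assay, the step to 6-bromo-1H-indol-2-yl on the carbonyl carbon gives (a 1.3-fold higher number from compound 3 to compound 4 (0.13 log units; within the scatter)), so the hydroxy can be exchanged for a bromine here without a change beyond the scatter, although the entering group has fewer hydrogen-bond donors and no hydrogen-bond acceptor. Compound 4 also lies within the scatter of compound 1 (a 1.7-fold higher number from compound 1 to compound 4 (0.23 log units; within the scatter)) but stays apart from compound 2 (a 2.5-fold lower number from compound 2 to compound 4 (0.39 log units; beyond the scatter)), which leaves compound 2, with its (1H-indol-3-yl)methyl group, as the only one of the four set apart from the rest. Nothing shown gives a reason for these steps.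

The substituent and its place on the indole change together here, so their contributions cannot be separated. As far as these compounds go, how an amine or a carboxylic acid on the indole, or a longer chain on the carbonyl carbon, would read in this assay remains open.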